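Amine aryl substituent change in a modulator series

The compounds below may be only part of what the source reports. "The series", "measured", "known", "first", "only" and "open" are said of these compounds alone.

Of the compounds shown here, three carry numbers so far. In an assay on HBE cells for positive allosteric modulation of Cystic fibrosis transmembrane conductance regulator variant F508del (Homo sapiens) (a higher number here means that more compound is needed for the effect, a lower number that less compound is needed), compound 1 `COc1ccc(C(C)C)cc1CN[C@H]1[C@H](C(C)(C)C)[C@@H](C(=O)O)N(C(=O)C2CCCCC2)[C@H]1c1ccccc1` gives 188 nM, compound 2 `COc1ccc(C(C)(C)C)cc1CN[C@H]1[C@H](C(C)(C)C)[C@@H](C(=O)O)N(C(=O)[C@@H]2CCCCO2)[C@H]1c1ccccc1` gives 321 nM, and compound 3 `CC(C)c1ccccc1[C@H]1[C@@H](Nc2cccnc2N(C)C)[C@H](C(C)(C)C)[C@@H](C(=O)O)N1C(=O)[C@@H]1CCCCO1` gives 142 nM. Compound 3 has the lowest of the three numbers; its gap to compound 1 lies within the scatter, while its gap to compound 2 lies beyond it. Compound 4 `Cc1ccccc1N[C@H]1[C@H](C(C)(C)C)[C@@H](C(=O)O)N(C(=O)[C@@H]2CCCCO2)[C@H]1c1ccccc1C(C)C` differs from compound 3 in one place: 2-methylphenyl in place of 2-(dimethylamino)pyridin-3-yl on an amine nitrogen. Within the data shown here, no measured pair shows this change, so its size has no direct precedent; the other two compounds give numbers in the same region as compound 3. A small shift toward a higher number is expected, a 1.7-fold higher number from compound 3 to compound 4 (0.23 log units; within the scatter), probably not beyond the scatter. Compound 4 is estimated at 240 nM, with a range from 90 nM to 650 nM.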

Compound 4, half-maximal effective concentration: 22 nM
Compound 4: the middle estimate sits 11-fold (1.04 log units) above what was measured, and the stated range ends above it.
By their numbers in this assay, from the lowest: compound 4; then compounds 3, 1 and 2 (each within the scatter of the next, the first and the last beyond it).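

Among these compounds, on the amine nitrogen, 2-methylphenyl in place of 2-(dimethylamino)pyridin-3-yl gives a 6.5-fold lower number from compound 3 to compound 4 (0.81 log units; beyond the scatter) in this assay and is the first single-place step available. Among the compounds shown here, the group on this nitrogen can therefore move the number beyond the scatter, and a group with no hetero atom and no hydrogen-bond acceptors is compatible with the lowest number so far. Nothing available accounts for the size of this step. The compounds shown leave open which part of the change carries the step: the ring nitrogen, the dimethylamino group or the methyl. Going by these compounds, how an unsubstituted phenyl or a 2-methoxyphenyl on this nitrogen would read also remains open.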